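Thiophen-2-yl in place of pyridin-2-yl

This account rests on a few compounds, and the source may have more. Where it says the series, first, only, none or still open, it means among the compounds named here.

In an ADME assay on S9 fraction from liver (Rattus norvegicus) for metabolic stability, read by LC-MS, using NADPH, with a stated time of 30 min (on this read-out higher numbers stand for a more stable compound and lower numbers for a less stable compound), compound 1 `CCCCCCCCc1ccc(OCC(=O)Cn2ncnn2)cc1` gives < 5%, which is a limit of the assay and not a number. Compound 2 `CCCCCCCCc1ccc(OCC(=O)Cn2nnc(-c3ccccc3)n2)cc1` gives 33%, and compound 3 `CCCCCCCCc1ccc(OCC(=O)Cn2nnc(-c3ccccn3)n2)cc1` gives 30%. Compound 3 thus stands level with compound 2, the step being a number 3 percentage points lower from compound 2 to compound 3 (within the scatter). Phenyl in place of hydrogen on an aromatic carbon gave a number at least 28 percentage points higher from compound 1 to compound 2 (beyond the scatter), and pyridin-2-yl in its place gave a number at least 25 percentage points higher from compound 1 to compound 3 (beyond the scatter).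

Compound 4 `CCCCCCCCc1ccc(OCC(=O)Cn2nnc(-c3cccs3)n2)cc1` carries thiophen-2-yl in place of pyridin-2-yl on an aromatic carbon of a five-membered aromatic ring with 4 nitrogen (thiophen-2-yl in place of pyridin-2-yl on an aromatic carbon). Within the data shown here, an aromatic ring therefore stays at this position, and the closest precedent is the exchange of one ring for another in compound 3, a number 3 percentage points lower from compound 2 to compound 3 (within the scatter). Among the measured compounds shown here, no thiophen-2-yl compound has been measured yet, so the range stays wide. The expected size is no step beyond the scatter, with an estimated a number 1 percentage points lower from compound 3 to compound 4 (within the scatter). Compound 4 is expected at 29%, with an estimated range from 14% to 45%.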

Compound 4, percent of the compound remaining: 8%
For compound 4 the middle estimate is 21 percentage points above the measured one, outside the stated range (below it).
By their numbers in this assay, from the lowest: compound 4; then compounds 3 and 2 (each within the scatter of the next). At a limit, below all of these: compound 1.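

Compounds 2 and 3 could suggest that any aromatic ring at this position serves equally, but in this assay thiophen-2-yl does not hold up. There is a number 22 percentage points lower from compound 3 to compound 4 (beyond the scatter) and likewise a number 25 percentage points lower from compound 2 to compound 4 (beyond the scatter) with this ring in place. The position therefore distinguishes among aromatic rings, and the level shared by phenyl and pyridin-2-yl does not extend to every ring placed there. The comparison with compound 1 gives only a number at least 3 percentage points higher from compound 1 to compound 4 (that floor lies within the scatter) and its size cannot be read. Compound 1 stands at a limit of the assay and not at a number: the limit of < 5% in this assay, at which 1 of the 4 values shown sits.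

Thiophen-2-yl differs from pyridin-2-yl in both ring size and hetero atom, so these compounds cannot separate the contribution of the sulfur from that of the five-membered ring. Where furan-2-yl or thiophen-3-yl would fall at this position remains open.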